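This account rests on a few compounds, and the source may have more. Where it says the series, first, only, none or still open, it means among the compounds named here.

Compound 3 `COc1ccccc1C(=O)Nc1ccc(Sc2nc3ccccc3s2)c(Cl)c1` stands at the limit of an assay for inhibition of HSP60/HSP10 (Homo sapiens), with a stated time of 60 min; on this read-out lower numbers stand for stronger inhibition and higher numbers for weaker inhibition: in this assay compound 3 gives > 100000 nM, which is a limit and not a number. Compound 1 `O=C(Nc1ccc(Sc2nc3ccccc3s2)c(Cl)c1)c1cc(Br)cc(Br)c1` also sits at a limit, giving > 100000 nM in this assay. Compound 2 `O=C(Nc1ccc(Sc2nc3ccccc3s2)c(Cl)c1)c1cccc(Br)c1O` is the only one of the three with a measured number, giving 6900 nM in this assay. The two limits are the same one (the limit of > 100000 nM in this assay, at which 2 of the 3 values shown sit). Compound 4 `O=C(Nc1ccc(Sc2nc3ccccc3s2)c(Cl)c1)c1cc(Br)ccc1O` differs from compound 3 by 5-bromo-2-hydroxyphenyl in place of 2-methoxyphenyl on a carbonyl carbon. This change runs close to the reverse of an at least 14-fold higher number from compound 2 to compound 3 (1.16 log units; beyond the scatter), with 5-bromo-2-hydroxyphenyl entering here rather than 3-bromo-2-hydroxyphenyl. The other measured step that brought 3-bromo-2-hydroxyphenyl in, an at least 14-fold lower number from compound 1 to compound 2 (1.16 log units; beyond the scatter), also lowered the number by a large amount. Compound 4 is therefore expected to move off the limit by a step of an at least 6.6-fold lower number from compound 3 to compound 4 (0.82 log units; beyond the scatter), in the direction of stronger inhibition. Compound 4 is estimated at 15000 nM, with a range from 4000 nM to 100000 nM.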

Compound 4, half-maximal inhibitory concentration: > 100000 nM
Compound 4 gave a limit, no number; the forecaster's own chance of this, stated with the estimate: 25%; middle value at least 6.6-fold (0.82 log units) away from the limit.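

In this assay, 5-bromo-2-hydroxyphenyl in place of 3-bromo-2-hydroxyphenyl on the carbonyl carbon gives an at least 14-fold higher number from compound 2 to compound 4 (1.16 log units; beyond the scatter), so these two groups, which differ only in where the bromine stands, are not interchangeable at this place. Having both a hydroxy and a bromine on this ring is therefore not enough in itself: compound 4 carries both and stays at the limit, and of the compounds shown only compound 2 gives a measured number. The steps from compound 1 and from compound 3 to compound 4 cannot be read, with both ends of each at one limit: the limit of > 100000 nM in this assay, at which 3 of the 4 values shown sit.

The compounds shown leave open how the hydroxy and the bromine of compound 2 each contribute to its inhibition. They also leave open whether an amine or a carboxylic acid in place of that hydroxy would keep a measurable value.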